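Methyl added to a fluorinated anilide: what to expect

A few compounds are considered here, and "the series" means these few. Any claim that something is new, unique, unknown or untested is made for them only; others in the source may bear on it.

Measured compounds:
- Compound 1 `Cc1cccc(-c2ccnc(C(=O)Nc3ccc(Oc4ccnc5[nH]ccc45)cc3)c2)c1` gives 7470 nM in a functional assay on MCF7 cells (Homo sapiens) for cytotoxicity, read by MTT assay, with a stated time of 72 h; on this read-out higher numbers stand for weaker inhibition and lower numbers for stronger inhibition.
- Compound 2 `O=C(Nc1ccc(Oc2ccnc3[nH]ccc23)cc1)c1cc(-c2ccccc2)ccn1` gives 3750 nM in this assay.
- Compound 3 `O=C(Nc1ccc(Oc2ccnc3[nH]ccc23)c(F)c1)c1cc(-c2ccccc2)ccn1` gives > 10000 nM in this assay, and this is a limit of the assay rather than a number.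

Compound 3 sits at the limit of > 10000 nM in this assay, at which 1 of the 3 values shown sits, so only a limit is known for it, and no exact figure can be compared with the other two.

Compound 4 `Cc1cccc(-c2ccnc(C(=O)Nc3ccc(Oc4ccnc5[nH]ccc45)c(F)c3)c2)c1` differs from compound 3 by methyl in place of hydrogen on an aromatic carbon. Among the measured compounds shown here, two measured steps bear on this. The first, an at least 2.6-fold higher number from compound 2 to compound 3 (0.42 log units; beyond the scatter), is the change that compound 3 already carries relative to compound 2, so it sets the starting point but does not describe the methyl itself. The second, a 2.0-fold lower number from compound 1 to compound 2 (0.30 log units; within the scatter), is exactly the methyl change in reverse, and it lay within the scatter. The methyl is therefore expected to leave the read-out essentially unchanged, with no step beyond the scatter in either direction.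

Compound 4 is thus estimated at 15000 nM, within a range of 6000 nM to 40000 nM, which corresponds to an expected step that the limit leaves unreadable from compound 3 to compound 4. Since compound 3 already sits at the limit, compound 4 is expected most likely to be reported as a limit as well.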

Compound 4, half-maximal inhibitory concentration: 9120 nM
Estimate against measurement, compound 4: 1.6-fold (0.22 log units) above, within the range that was stated.
By their numbers in this assay, from the lowest: compounds 2, 1 and 4 (each within the scatter of the next, the first and the last beyond it). At a limit, above all of these: compound 3.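

In this assay the figure for compound 3, > 10000 nM, is a limit and not a number. Adding the methyl therefore gives only a floor for its effect on the fluorinated compounds, an at least 1.0-fold lower number from compound 3 to compound 4 (0.04 log units; that floor lies within the scatter), and this floor cannot show whether the methyl matters more or less here than it does without the fluoro: the same change on two cores in this assay, a 2.0-fold lower number (0.30 log units; within the scatter) from compound 1 to compound 2 and an at least 1.0-fold higher number (0.04 log units; that floor lies within the scatter) from compound 4 to compound 3; the limit leaves it open whether they differ. The new result does show that the fluoro need not bring a step beyond the scatter, since on the 3-methylphenyl compounds it reads a 1.2-fold higher number from compound 1 to compound 4 (0.09 log units; within the scatter), whereas on the phenyl compounds it reads an at least 2.6-fold higher number from compound 2 to compound 3 (0.42 log units; beyond the scatter), and still the two cannot be told apart with certainty: the same change on two cores in this assay, an at least 2.6-fold higher number (0.42 log units; beyond the scatter) from compound 2 to compound 3 and a 1.2-fold higher number (0.09 log units; within the scatter) from compound 1 to compound 4; the limit leaves it open whether they differ.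

The compounds shown leave open whether the fluoro step truly depends on the methyl, a question that an exact figure for compound 3 would settle. They also leave open whether another group at this place on the ring, such as a methoxy group, an amine or a carboxylic acid, would move the number beyond the scatter.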